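A few compounds are considered here, and "the series" means these few. Any claim that something is new, unique, unknown or untested is made for them only; others in the source may bear on it.

Measured so far:
Compound 1, `N=C(N)N/N=C/c1c(-c2cccs2)nc2sccn12`, 6760 nM.
Compound 2, `Cc1cn2c(/C=N/NC(=N)N)c(-c3cccs3)nc2s1`, 1820 nM.

In a functional assay on cells (Leukemia cell, Homo sapiens) for inhibition (a lower number here means a stronger inhibitor of growth, a higher number a weaker inhibitor of growth), compound 1 gives the higher of the two numbers, so it is the weaker of the pair. Among the measured compounds shown here, the one measured step, a 3.7-fold lower number from compound 1 to compound 2 (0.57 log units; beyond the scatter), comes from a methyl in place of hydrogen on an aromatic carbon of the shared core.

Compound 3, `Cc1cc(-c2nc3sccn3c2/C=N/NC(=N)N)c(C)s1`, differs from compound 1 in another way: 2,5-dimethylthiophen-3-yl in place of thiophen-2-yl on an aromatic carbon. For the measured compounds named here, no measured step touches the thiophene ring itself, so the only guide is that a single added methyl elsewhere on the core of compound 1 moved the number by a 3.7-fold lower number from compound 1 to compound 2 (0.57 log units; beyond the scatter). The change here is larger, adding two methyls and shifting the point where the thiophene ring is joined, and its effect cannot be read off from that one step. A small step in the same direction seems plausible, but a step of no size beyond the scatter is just as credible.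

Compound 3 is therefore expected to give about 3500 nM, with a likely range of 1000 nM to 12000 nM, meaning an estimated step of a 1.9-fold lower number from compound 1 to compound 3 (0.29 log units; within the scatter).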

Compound 3, concentration for 50% growth inhibition: 15500 nM
Estimate against measurement, compound 3: 4.4-fold (0.65 log units) below; the whole stated range lies below it.
By their numbers in this assay, from the lowest: compound 2; then compound 1; then compound 3.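

Among the compounds shown here, replacing thiophen-2-yl with 2,5-dimethylthiophen-3-yl gives a 2.3-fold higher number from compound 1 to compound 3 (0.36 log units; beyond the scatter) in this assay, which is the first sign that the group on this aromatic carbon affects growth inhibition and that this replacement weakens it. The direction is opposite to that of the earlier change on the shared core, a 3.7-fold lower number from compound 1 to compound 2 (0.57 log units; beyond the scatter), so among these compounds, a change that adds methyl groups does not always lower the number. Nothing available here explains why this replacement gives a weaker inhibitor of growth.

This single step combines two changes, the added methyl groups and the different point of attachment of the thiophene ring, so it cannot show how much each contributes to the result. It also leaves open how plain thiophen-3-yl, a thiophene ring bearing one methyl, or quite different groups at this place, such as phenyl or an amine, would compare with thiophen-2-yl in this assay.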